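A few compounds are considered here, and "the series" means these few. Any claim that something is new, unique, unknown or untested is made for them only; others in the source may bear on it.

Measured so far:
compound 1, `O=C1/C(=C/c2ccc(F)cc2)CCC/C1=C\c1ccccc1[N+](=O)[O-]`: 11000 nM.
compound 2, `O=C1/C(=C/c2ccc(Cl)cc2)CCC/C1=C\c1ccccc1[N+](=O)[O-]`: 400000 nM.
compound 3, `O=C1/C(=C/c2ccc(F)cc2)CCC/C1=C\c1ccc([N+](=O)[O-])cc1`: only a limit, > 400000 nM.

All three were examined in an ADME assay on HPC cells (Homo sapiens) for cytotoxicity, with a stated time of 24 h; a lower number here means that less compound is tolerated, a higher number that more compound is tolerated. In this assay compound 1 gives 11000 nM, and compound 2 gives 400000 nM. For compound 3 the assay reports a limit rather than a number, > 400000 nM, which is the limit of > 400000 nM in this assay, at which 1 of the 3 values shown sits.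

The change from compound 1 to compound 2 is chloro in place of fluoro on an aromatic carbon, and it made a 36-fold higher number from compound 1 to compound 2 (1.56 log units; beyond the scatter). Compound 4, `O=C1/C(=C/c2ccc(Cl)cc2)CCC/C1=C\c1ccc([N+](=O)[O-])cc1`, has not been measured. It differs from compound 3 by chloro in place of fluoro on an aromatic carbon, the same change at the same place. The difference between the core of compound 3 and the core of compound 1 is not broken down here.

Compound 3 already sits at the limit of the assay, so the step from compound 3 to compound 4 is expected to be a number no higher from compound 3 to compound 4 (the limit leaves the size open), and a higher number would most likely again be reported only as a limit. Compound 4 is therefore expected to give about 400000 nM, estimated between 150000 nM and 1500000 nM.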

Compound 4, half-maximal cytotoxic concentration: 345000 nM
The estimate for compound 4 lay 1.2-fold (0.06 log units) above the measured number; the range from low to high includes it.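

In this assay the change from fluoro to chloro gave an at least 1.1-fold lower number from compound 3 to compound 4 (0.06 log units; that floor lies within the scatter), so the large rise seen on the core of compound 1 did not appear on the core of compound 3. The change therefore did not carry from one core to the other in these two pairs: the same change on two cores in this assay, a 36-fold higher number (1.56 log units; beyond the scatter) from compound 1 to compound 2 and an at least 1.1-fold lower number (0.06 log units; that floor lies within the scatter) from compound 3 to compound 4, at least 42-fold (1.62 log units) apart, beyond the scatter of two such steps
Compound 3 is recorded only as > 400000 nM, a limit and not a number, so the true size of the step on its core is not shown, and two pairs do not show how the change would behave on any further core.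

From the compounds shown here alone, whether a bromo or a methoxy group on the same aromatic carbon would follow the core of compound 1 or the core of compound 3 stays open. So does whether the two cores would also part ways with an amine or a carboxylic acid in that place, and these four compounds give no reason for the difference between the cores.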